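This account rests on a few compounds, and the source may have more. Where it says the series, first, only, none or still open, it means among the compounds named here.

Compound 3 `CCN(CC)CCCNc1ccc(S(=O)(=O)NC(=O)c2ccc(N3CCN(CC4=C(c5ccc(C(F)(F)F)cc5)CC(C)(C)CC4)CC3)cc2Oc2cnc3[nH]ccc3c2)cc1[N+](=O)[O-]` gives the lowest number of the three measured, with 0.3 nM in an assay on isolated protein for displacement of a labelled ligand from Apoptosis regulator Bcl-2 (Homo sapiens), with a stated time of 15 min; a lower number here means a stronger inhibitor, a higher number a weaker inhibitor. Among the compounds with values here, compound 2 `CC1(C)CCC(CN2CCN(c3ccc(C(=O)NS(=O)(=O)c4ccc(NCC5CCOCC5)c([N+](=O)[O-])c4)c(Oc4cnc5[nH]ccc5c4)c3)CC2)=C(c2ccc(C(F)(F)F)c(Cl)c2)C1` gives 0.8 nM, and compound 1 `CC1(C)CCC(CN2CCN(c3ccc(C(=O)NS(=O)(=O)c4ccc(NCC5CCOCC5)c([N+](=O)[O-])c4)c(Oc4cnc5[nH]ccc5c4)c3)CC2)=C(c2ccccc2C(F)(F)F)C1` gives 1.7 nM; the only single-point step among them is a 2.1-fold lower number from compound 1 to compound 2 (0.33 log units; beyond the scatter). Compound 4 `CC1(C)CCC(CN2CCN(c3ccc(C(=O)NS(=O)(=O)c4ccc(NCC5CCOC5)c([N+](=O)[O-])c4)c(Oc4cnc5[nH]ccc5c4)c3)CC2)=C(c2ccc(C(F)(F)F)cc2)C1` differs from compound 3 by oxolan-3-yl in place of 2-(diethylamino)ethyl on a saturated chain carbon bound to a nitrogen on an aromatic ring. Within the data shown here, no measured step covers this change; compounds 1 and 2 carry a different cyclic-ether chain at the same place alongside other changes, so their values show only that such chains sit in the same low range. The step from compound 3 to compound 4 is therefore expected to be small, likely a somewhat higher number, a 2.7-fold higher number from compound 3 to compound 4 (0.43 log units; beyond the scatter). Compound 4 is estimated at 0.8 nM, within 0.3 nM to 2.5 nM.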

Compound 4, half-maximal inhibitory concentration: 4.7 nM
Beside the measured number, compound 4's estimate is 5.9-fold (0.77 log units) below it, and the stated range ends below it.
By their numbers in this assay, from the lowest: compound 3; then compound 2; then compound 1; then compound 4.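

Placing oxolan-3-yl in place of 2-(diethylamino)ethyl on a saturated chain carbon bound to a nitrogen on an aromatic ring gives, in this assay, a 16-fold higher number from compound 3 to compound 4 (1.19 log units; beyond the scatter), so the value depends strongly on what this place carries. Both groups count the same hydrogen-bond acceptors and no net charge, so those counts do not track the step. Nothing measured here explains it.

From the compounds shown here alone, the amine, the ring and the chain size all change together, and which of them matters stays open. A methoxy-ended open chain or a piperidine ring at this place could separate them.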